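The source may report more compounds than this note shows. Statements on the series, on what has been measured and on what is new or still open speak of the compounds shown alone.

Working notes on the series. Compound 1 `O=C(CCCOc1no[n+]([O-])c1S(=O)(=O)c1ccccc1)NO` is the reference point: in a functional assay on HEL cells (Homo sapiens) for inhibition, read by MTT assay, with a stated time of 48 h (a lower number here means a stronger inhibitor, a higher number a weaker inhibitor), compound 1 gives 670 nM. Among the measured compounds shown here, compound 2 `O=C(CCCCCCOc1no[n+]([O-])c1S(=O)(=O)c1ccccc1)NO` carries the longer chain, and in this assay compound 2 gives 9330 nM, the highest of the two numbers so far; the only step measured, a 14-fold higher number from compound 1 to compound 2 (1.14 log units; beyond the scatter), is large. Compound 3 `O=C(NO)OCCOCCOc1no[n+]([O-])c1S(=O)(=O)c1ccccc1` is not yet measured. Its change from compound 2 is 2-((hydroxycarbamoyl)oxy)ethoxy in place of 4-(hydroxycarbamoyl)butyl on a saturated chain carbon, two bonds along the chain from an oxygen on an aromatic ring. That step keeps the chain length of compound 2, so the measured step, which concerns chain length alone, gives little direct guidance; an expected step of a 1.2-fold lower number from compound 2 to compound 3 (0.07 log units; within the scatter) in this assay is therefore modest and uncertain. For compound 3 the estimate in this assay is 8000 nM, within 2500 nM to 25000 nM.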

Compound 3, half-maximal inhibitory concentration: 3730 nM
Estimate against measurement, compound 3: 2.1-fold (0.33 log units) above; the range from low to high includes it.
By their numbers in this assay, from the lowest: compound 1; then compound 3; then compound 2.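

In this assay, 2-((hydroxycarbamoyl)oxy)ethoxy in place of 4-(hydroxycarbamoyl)butyl, a swap with the same heavy-atom count, gives a 2.5-fold lower number from compound 2 to compound 3 (0.40 log units; beyond the scatter), so at this place the number responds to the make-up of the chain and not only to its length. The same entering group set against the shorter chain gives a 5.6-fold higher number from compound 1 to compound 3 (0.75 log units; beyond the scatter), which leaves compound 1 with the lowest number of the three. No measured evidence accounts for either step. Still open, as far as these compounds go, is whether a carboxylic acid or a primary amide at the chain end would keep any of this activity, and whether a shorter chain carrying the ether oxygen would reach the number of compound 1.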